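Methoxy count on the aryl ring of the pyrazole series

The source may report more compounds than this note shows. Statements on the series, on what has been measured and on what is new or still open speak of the compounds shown alone.

Measured so far in a functional assay on HCT-116 cells (Homo sapiens) for cytotoxicity, read by sulforhodamine B assay, with a stated time of 48 h, tested at 100 uM; a lower number here means a stronger effect, a higher number a weaker effect of the compound at the concentration tested:
- compound 1 `COc1ccc(-c2cc(/C=C/C(=O)c3ccc(N)cc3)[nH]n2)cc1`: -15%
- compound 2 `COc1cc(-c2cc(/C=C/C(=O)c3ccc(N)cc3)[nH]n2)cc(OC)c1OC`: -73%
- compound 3 `COc1cc(-c2cc(/C=C/C(=O)c3ccc(Cl)c(Cl)c3)[nH]n2)cc(OC)c1OC`: -32%

Compound 2 gives the lowest of the three numbers; compound 3 sits a number 41 percentage points higher from compound 2 to compound 3 (beyond the scatter), and compound 1 stands furthest away. For the measured compounds named here, the one step that runs through a single change is the exchange on the carbonyl carbon, 3,4-dichlorophenyl in place of 4-aminophenyl, which was large. Going by the values given here, no single step links compound 1 and compound 2, which differ in two places; their two values simply show a weaker effect for the single methoxy and a stronger one for the three.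

Compound 4 `COc1ccc(-c2cc(/C=C/C(=O)c3ccc(N)cc3)[nH]n2)cc1OC` is the next compound. Relative to compound 2 the change is hydrogen in place of methoxy on an aromatic carbon, on a ring carbon that is ortho to a methoxy group and meta to a methoxy group. Among the compounds with values here, no measured step bears directly on the loss of one methoxy, so the expectation rests on the span between compound 1 and compound 2: a step upward from compound 2, beyond the scatter, is expected but with wide uncertainty. Compound 4 is estimated at -45%, within -75% to -15%, meaning an expected step of a number 28 percentage points higher from compound 2 to compound 4 (beyond the scatter).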

Compound 4, a percentage reported as activity, at one concentration (the size of the read-out at that concentration, not a potency): -89%
For compound 4 the middle estimate is 44 percentage points above the measured one; the whole stated range lies above it.
By their numbers in this assay, from the lowest: compound 4; then compound 2; then compound 3; then compound 1.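

In this assay this methoxy is dispensable: hydrogen in its place gives a number 16 percentage points lower from compound 2 to compound 4 (beyond the scatter) and so keeps the strong effect instead of losing it. Methoxy in place of hydrogen on the other side of the set gives a number 74 percentage points lower from compound 1 to compound 4 (beyond the scatter) and is a far larger step, so the read-out does not follow the methoxy count in one direction, with compound 2 going against any rise with each added methoxy. No supporting data on the cause of either step are available here.

Still open, as far as these compounds go, is whether this place tolerates groups other than methoxy and hydrogen, such as hydroxyl or ethoxy. Also open, from the compounds shown here alone, is whether the same hydrogen for methoxy exchange behaves alike when 3,4-dichlorophenyl stands on the carbonyl carbon.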